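The source may report more compounds than this note shows. Statements on the series, on what has been measured and on what is new or still open speak of the compounds shown alone.

The measured compounds and their values in a functional assay on cells for inhibition, with Murine T-cell line (Mus musculus) as the target; a lower number here means a stronger inhibitor, a higher number a weaker inhibitor:

Compound 1, `CC[C@@H]1/C=C(\C)C[C@H](C)C[C@H](OC)[C@H]2O[C@@](O)(C(=O)C(=O)N3CCCC[C@H]3C(=O)O[C@H](/C(C)=C/[C@@H]3CC[C@@H](Oc4ccc(C)cc4)[C@H](OC)C3)[C@H](C)[C@@H](O)CC1=O)[C@H](C)C[C@@H]2OC`: compound 1 gives 2.7 nM
Compound 2, `CC[C@@H]1/C=C(\C)C[C@H](C)C[C@H](OC)[C@H]2O[C@@](O)(C(=O)C(=O)N3CCCC[C@H]3C(=O)O[C@H](/C(C)=C/[C@@H]3CC[C@@H](O)[C@H](Oc4ccccc4)C3)[C@H](C)[C@@H](O)CC1=O)[C@H](C)C[C@@H]2OC`: compound 2 gives 3.2 nM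
Compound 3, `CC[C@@H]1/C=C(\C)C[C@H](C)C[C@H](OC)[C@H]2O[C@@](O)(C(=O)C(=O)N3CCCC[C@H]3C(=O)O[C@H](/C(C)=C/[C@@H]3CC[C@@H](O)[C@H](Oc4ccc(OC)cc4)C3)[C@H](C)[C@@H](O)CC1=O)[C@H](C)C[C@@H]2OC`: compound 3 gives 0.9 nM

Compound 1 stands second highest of the three numbers. Compound 2 sits within the scatter of it, so the two cannot be told apart, while compound 3 lies beyond the scatter below it. Compound 4, `CC[C@@H]1/C=C(\C)C[C@H](C)C[C@H](OC)[C@H]2O[C@@](O)(C(=O)C(=O)N3CCCC[C@H]3C(=O)O[C@H](/C(C)=C/[C@@H]3CC[C@@H](Oc4ccc(OC)cc4)[C@H](OC)C3)[C@H](C)[C@@H](O)CC1=O)[C@H](C)C[C@@H]2OC`, is not yet measured. It differs from compound 1 in one place: methoxy in place of methyl on an aromatic carbon, so the 4-methylphenoxy group becomes a 4-methoxyphenoxy group.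

Going by the values given here, the only measured step with a related change is a 3.6-fold lower number from compound 2 to compound 3 (0.55 log units; beyond the scatter), where a methoxy group entered an aromatic ring of the same kind, though there it replaced hydrogen rather than methyl and the ring sat on a different carbon of the shared core. That step lowered the number modestly. For compound 4 a smaller lowering is therefore expected, roughly a 1.8-fold lower number from compound 1 to compound 4 (0.26 log units; within the scatter), with a fair chance that it stays within the scatter. The expected value for compound 4 is 1.5 nM, with a range from 0.6 nM to 4 nM.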

Compound 4, half-maximal inhibitory concentration: 1.4 nM
Estimate against measurement, compound 4: 1.1-fold (0.03 log units) above, and the stated range covers the measured number.
By their numbers in this assay, from the lowest: compounds 3, 4, 1 and 2 (each within the scatter of the next, the first and the last beyond it).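

In this assay, replacing the methyl of the 4-methylphenoxy group with methoxy gives a 1.9-fold lower number from compound 1 to compound 4 (0.29 log units; within the scatter) and so the methyl and methoxy forms at this ring carbon, para to a large group, cannot be told apart. The earlier methoxy step, a 3.6-fold lower number from compound 2 to compound 3 (0.55 log units; beyond the scatter) and beyond the scatter, differs in two ways: there methoxy replaced hydrogen, and its ring sat on a different carbon of the shared core, so these compounds cannot show which difference matters. No measurement offered here explains why this swap at this position gives the number it does.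

Still open, as far as these compounds go, is how a plain phenoxy ring on this carbon of the core would compare with the methyl and methoxy forms. Also open, from the compounds shown here alone, is what a chlorine, an amine or an ethoxy group at this same ring carbon would give.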